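This account rests on a few compounds, and the source may have more. Where it says the series, first, only, none or still open, it means among the compounds named here.

Compound 1 `ClCc1ccccc1Cn1cnc2c(Cl)nc(Cl)nc21` and compound 2 `ClCc1cccc(Cn2cnc3c(Cl)nc(Cl)nc32)c1` are built from the same atoms joined differently; the difference between the two cores is not broken down here. In a functional assay on SK-MEL-5 cells (Homo sapiens) for cytotoxicity, read by sulforhodamine B assay, with a stated time of 48 h (a lower number here means a stronger inhibitor of growth, a higher number a weaker inhibitor of growth), compound 1 gives 420 nM, and compound 2 gives 1580 nM. Compound 3 `Nc1nc(Cl)c2ncn(Cc3ccccc3CCl)c2n1` differs from compound 1 by the change (amino in place of chloro on an aromatic carbon), and in this assay compound 3 gives 8510 nM, so the step is a 20-fold higher number from compound 1 to compound 3 (1.31 log units; beyond the scatter). Compound 4 `Nc1nc(Cl)c2ncn(Cc3cccc(CCl)c3)c2n1`, not yet measured, differs from compound 2 by the change (amino in place of chloro on an aromatic carbon), which is the same change as that made between compound 1 and compound 3, with the same surroundings at the place of exchange. Only this one measured occurrence of the change is available, so any carry-over to the core of compound 2 rests on a single precedent. In this assay the expected step is a 19-fold higher number from compound 2 to compound 4 (1.28 log units; beyond the scatter), taken directly from the measured step of a 20-fold higher number from compound 1 to compound 3 (1.31 log units; beyond the scatter). Compound 4 is accordingly estimated at 30000 nM in this assay, with a plausible range from 8000 nM to 120000 nM.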

Compound 4, concentration for 50% growth inhibition: 11000 nM
The estimate for compound 4 lay 2.7-fold (0.44 log units) above the measured number, within the range that was stated.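

In this assay, amino in place of chloro on an aromatic carbon again raises the number on the core of compound 2, and the step is a 7.0-fold higher number from compound 2 to compound 4 (0.84 log units; beyond the scatter), so the direction of the change held on both cores shown. The size of the step did not carry over unchanged, and the two occurrences differ: the same change on two cores in this assay, a 20-fold higher number (1.31 log units; beyond the scatter) from compound 1 to compound 3 and a 7.0-fold higher number (0.84 log units; beyond the scatter) from compound 2 to compound 4, 2.9-fold (0.46 log units) apart, beyond the scatter of two such steps For this series, the direction is therefore the better guide, while a step measured on one core is only a rough guide to its size on the other; two cores give no rule for further cores and do not show what sets the difference in size.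

The compounds shown leave open whether a methoxy group or a dimethylamino group at the same place would raise the number as amino does, and whether any such step would again depend on the core. Also open, from the compounds shown here alone, is how a hydroxymethyl group in place of the chloromethyl group would behave on either core.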